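Swapping the amino-linked ring for a dichlorophenyl on the carbonyl

The compounds below may be only part of what the source reports. "The series", "measured", "known", "first", "only" and "open" are said of these compounds alone.

Measured compounds:
compound 1 `COc1cc(Cl)cc(-c2nn(-c3cccc(NC(=O)Nc4cccc(C(F)(F)F)c4)c3)cc2-c2ccncc2)c1` 3.34%
compound 2 `COc1cc(Cl)cc(-c2nn(-c3cccc(NC(=O)Nc4ccc(Cl)c(C(F)(F)F)c4)c3)cc2-c2ccncc2)c1` 1.88%
compound 3 `COc1cc(Cl)cc(-c2nn(-c3cccc(NC(=O)c4cc(C(F)(F)F)cc(C(F)(F)F)c4)c3)cc2-c2ccncc2)c1` 57.1%

In a functional assay on CCRF-CEM cells (Homo sapiens) for inhibition, read by sulforhodamine B assay, with a stated time of 48 h, tested at 10 uM (a lower number here means a stronger effect, a higher number a weaker effect of the compound at the concentration tested), compound 1 gives 3.34%, the second highest of the three numbers; compound 2 sits nearest, compound 3 furthest. For the measured compounds named here, the one measured step, a number 1.5 percentage points lower from compound 1 to compound 2 (within the scatter), is within the scatter. Compound 4 `COc1cc(Cl)cc(-c2nn(-c3cccc(NC(=O)c4ccc(Cl)c(Cl)c4)c3)cc2-c2ccncc2)c1` differs from compound 1 by 3,4-dichlorophenyl in place of (3-(trifluoromethyl)phenyl)amino on a carbonyl carbon. Going by the values given here, no measured step covers this change directly. Compound 3, which also carries an aromatic ring directly on the carbonyl carbon, gives 57.1%, far beyond the scatter from compound 1. Compound 4 is therefore expected to move a large step upward, a number 41.7 percentage points higher from compound 1 to compound 4 (beyond the scatter), toward the number of compound 3. The estimate for compound 4 is 45%, expected between 15% and 75%.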

Compound 4, a percentage reported as activity, at one concentration (the size of the read-out at that concentration, not a potency): 59.2%
Beside the measured number, compound 4's estimate is 14.2 percentage points below it; low and high end bracket the measured number.
By their numbers in this assay, from the lowest: compounds 2 and 1 (each within the scatter of the next); then compounds 3 and 4 (each within the scatter of the next).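

In this assay, the change on this carbonyl carbon from (3-(trifluoromethyl)phenyl)amino to 3,4-dichlorophenyl gives a number 55.9 percentage points higher from compound 1 to compound 4 (beyond the scatter). The same kind of change from (4-chloro-3-(trifluoromethyl)phenyl)amino gives a number 57.3 percentage points higher from compound 2 to compound 4 (beyond the scatter), so the large rise appears with both amino-linked groups. No measurement available here explains this rise. On these data alone, it remains open whether the step follows the loss of the amino nitrogen or the change in the ring's substituents. A (3,4-dichlorophenyl)amino group on this carbonyl carbon would separate the two.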